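This account rests on a few compounds, and the source may have more. Where it says the series, first, only, none or still open, it means among the compounds named here.

Measured compounds:
- compound 1 `CCOCC12CCC(c3nnc(-c4ccccc4C(F)(F)F)n3C)(CC1)CC2`; in an assay on CHO-K1 cells for inhibition of 11-beta-hydroxysteroid dehydrogenase type 2 (Mus musculus), read by scintillation proximity assay (a lower number here means a stronger inhibitor, a higher number a weaker inhibitor), compound 1 gives > 4000 nM, a limit of the assay rather than a number.
- compound 2 `CCSCCC12CCC(c3nnc(-c4ccccc4C(F)(F)F)n3C)(CC1)CC2`; in this assay compound 2 gives > 4000 nM, again only a limit.
- compound 3 `Cn1c(-c2ccccc2C(F)(F)F)nnc1C12CCC(COc3ccc(S(C)(=O)=O)cc3)(CC1)CC2`; in this assay compound 3 gives > 4000 nM, also a limit.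

Compound 1 therefore stands only at a limit, and the two other values shown are limits as well (the limit of > 4000 nM in this assay, at which 3 of the 3 values shown sit). The steps among the measured compounds, a step that the two limits leave unreadable from compound 1 to compound 2, a step that the two limits leave unreadable from compound 1 to compound 3 and a step that the two limits leave unreadable from compound 2 to compound 3, cannot be read in size or direction for this reason.

Compound 4 `Cn1c(-c2ccccc2C(F)(F)F)nnc1C12CCC(CNS(C)(=O)=O)(CC1)CC2` differs from compound 1 by one change: methanesulfonamido in place of ethoxy on a saturated chain carbon bound to a saturated ring carbon. Among the measured compounds shown here, none of the measured steps gives a readable size, so no direction beyond the scatter can be expected from them; the only guide is that every value so far sits at the limit. Compound 4 is expected to show a step that the limit leaves unreadable from compound 1 to compound 4, most likely remaining at a limit. The estimate for compound 4 in this assay is 6000 nM, with a range from 1500 nM to 25000 nM.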

Compound 4, half-maximal inhibitory concentration: > 4000 nM
Compound 4 ended at the assay's limit; the forecaster's own chance of this, stated with the estimate: 70%; the middle value is on the limit's open side.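

No step from compound 1, compound 2 or compound 3 to compound 4 can be read, because all four compounds stand only at a limit: the limit of > 4000 nM in this assay, at which 4 of the 4 values shown sit.

The compounds shown leave open how strongly any of them acts in this assay, and whether any of these side-chain changes alters that.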